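Series notes: from compound 3 to compound 4

The compounds below may be only part of what the source reports. "The series", "measured", "known", "first", "only" and "open" are said of these compounds alone.

Measured in an ADME assay on microsomes from liver (Canis lupus familiaris) for metabolic stability, read by LC-MS, using NADPH, with a stated time of 10 min, tested at 0.1 uM; on this read-out lower numbers stand for slow clearance and higher numbers for fast clearance:
- compound 1 `COc1ccccc1N1C(=O)CSC1c1cc(F)cc(C(=O)NCCCCc2ccccc2)c1`: 2170 mL.min-1.g-1
- compound 2 `C#Cc1cc(C(=O)NCCCCc2ccccc2)cc(C2SCC(=O)N2c2ccccc2OC)c1`: 1750 mL.min-1.g-1
- compound 3 `O=C(NCCCCc1ccccc1)c1cccc(C2SCC(=O)N2c2cccc(-c3c[nH]nn3)c2)c1`: 226 mL.min-1.g-1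

Compound 3 has the lowest of the three numbers, beyond the scatter from both others. Compound 4 `CC(F)(F)c1cccc(N2C(=O)CSC2c2cccc(C(=O)NCCCCc3ccccc3)c2)c1` is the next to read, with 1,1-difluoroethyl in place of 1H-1,2,3-triazol-4-yl on an aromatic carbon. Among the measured compounds shown here, the only measured single-place step, a 1.2-fold lower number from compound 1 to compound 2 (0.09 log units; within the scatter), is a different change and lies within the scatter, so it offers no direct guide. Compound 1 at 2170 mL.min-1.g-1 and compound 2 at 1750 mL.min-1.g-1 also lack the 1H-1,2,3-triazol-4-yl group, although they differ from compound 3 elsewhere too. A rise beyond the scatter is therefore expected in this assay. The expected size is a 5.3-fold higher number from compound 3 to compound 4 (0.73 log units; beyond the scatter). The estimate for compound 4 is 1200 mL.min-1.g-1, with an expected range of 450 mL.min-1.g-1 to 2600 mL.min-1.g-1.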

Compound 4, intrinsic clearance in microsomes: 912 mL.min-1.g-1
Beside the measured number, compound 4's estimate is 1.3-fold (0.12 log units) above it; the range from low to high includes it.
By their numbers in this assay, from the lowest: compound 3; then compounds 4, 2 and 1 (each within the scatter of the next, the first and the last beyond it).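

In this assay the change to 1,1-difluoroethyl from 1H-1,2,3-triazol-4-yl gives a 4.0-fold higher number from compound 3 to compound 4 (0.61 log units; beyond the scatter) at this aromatic carbon, the one single-place step shown here that lies beyond the scatter. The read-out therefore responds to the group held at this position, where a five-membered aromatic ring gives way to a group with no ring. No measurement at hand bears on what lies behind this step.

The compounds shown leave open how a plain ethyl, an amine or a carboxylic acid on this carbon would read. They also leave open whether the step follows the departure of 1H-1,2,3-triazol-4-yl or the entry of 1,1-difluoroethyl.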